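Chloro for hydrogen on the acetyl-bearing ring

The source may report more compounds than this note shows. Statements on the series, on what has been measured and on what is new or still open speak of the compounds shown alone.

Three compounds in this series have numbers in an assay on isolated protein for inhibition of leukotriene B4 receptor 1 (Homo sapiens), tested at 10 uM; on this read-out lower numbers stand for less inhibition and higher numbers for more inhibition at the one concentration tested (going by the name of the read-out). Compound 1 `CC(=O)c1cc(C)c(OCCCCC#N)cc1O` gives 79%, compound 2 `CCCc1cc(C(C)=O)c(O)cc1OCCCCC#N` gives 84%, and compound 3 `CCCc1cc(C(C)=O)ccc1OCCCCC#N` gives 44%. Among the compounds with values here, the step of a number 5 percentage points higher from compound 1 to compound 2 (within the scatter) is small, while the step of a number 40 percentage points lower from compound 2 to compound 3 (beyond the scatter) is the one large change seen so far. Compound 3 therefore stands lowest of the three, with compound 1 and compound 2 both well above it beyond the scatter.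

Compound 4 `CCCc1cc(C(C)=O)c(Cl)cc1OCCCCC#N` carries a single change against compound 3: chloro in place of hydrogen on an aromatic carbon. The same position held the hydroxy group in compound 2, and removing it produced the large drop of a number 40 percentage points lower from compound 2 to compound 3 (beyond the scatter). Within the data shown here, whether chloro behaves like hydroxy or like hydrogen at this place cannot be read from the measured compounds; no step with chloro exists here. A partial recovery is the working expectation, but with wide uncertainty, so the step of a number 11 percentage points higher from compound 3 to compound 4 (beyond the scatter) is estimated as small and possibly within the scatter. In this assay compound 4 is therefore expected to give about 55%, with a range from 30% to 80%.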

Compound 4, a percentage reported as inhibition, at one concentration (the size of the read-out at that concentration, not a potency): 35%
Compound 4: middle estimate off by 20 percentage points, on the high side; the range from low to high includes it.
By their numbers in this assay, from the lowest: compounds 4 and 3 (each within the scatter of the next); then compounds 1 and 2 (each within the scatter of the next).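

In this assay, the step of a number 9 percentage points lower from compound 3 to compound 4 (within the scatter) puts chloro level with hydrogen at this place, ortho to an acetyl group and para to a propyl group, so compound 4 reads like the compound without a substituent there. The step of a number 49 percentage points lower from compound 2 to compound 4 (beyond the scatter) shows that the loss seen on removing hydroxy also appears when chloro takes its place, so among these three compounds only the hydroxy compound holds the high number. No measurement here bears on why chloro and hydrogen read alike at this place. Hydroxy remains the only group at this place that gives a high number, and it is open whether an amine or a methoxy group would read like hydroxy or like hydrogen. Also open, on these data alone, is whether chloro would read the same with methyl in place of the propyl group.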